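Heptyl extension of the chloro compound in the series

A few compounds are considered here, and "the series" means these few. Any claim that something is new, unique, unknown or untested is made for them only; others in the source may bear on it.

In an ADME assay on J774 cells (Mus musculus) for cytotoxicity (a higher number here means that more compound is needed for the effect, a lower number that less compound is needed), the three measured compounds differ only in the halogen on an aromatic carbon. Compound 1 `CCc1c(C)[nH]c2cc(OC)c(F)cc2c1=O` gives 9400 nM. Compound 2 `CCc1c(C)[nH]c2cc(OC)c(Cl)cc2c1=O` gives 19000 nM, the higher of the two numbers, and compound 1 is its nearest neighbour. Compound 3 `CCc1c(C)[nH]c2cc(OC)c(Br)cc2c1=O` gives > 33900 nM, which is a limit of the assay and not a number.

Compound 4 `CCCCCCCCCc1c(C)[nH]c2cc(OC)c(Cl)cc2c1=O` departs from compound 2 by heptyl in place of hydrogen on a saturated chain carbon, two bonds along the chain from an aromatic carbon.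

The halogen swaps show a 2.0-fold higher number from compound 1 to compound 2 (0.31 log units; beyond the scatter) and an at least 3.6-fold higher number from compound 1 to compound 3 (0.55 log units; beyond the scatter), both beyond the scatter, while an at least 1.7-fold higher number from compound 2 to compound 3 (0.25 log units; that floor lies within the scatter) has a floor within it. These steps bear only indirectly, as they show how far the number moves within the series. Among the measured compounds shown here, no measured step alters the chain, so the direction is weakly founded. A modest move to a lower number is expected, of about the size of the smallest step beyond the scatter, and the range is kept wide on both sides. The estimated step is a 2.1-fold lower number from compound 2 to compound 4 (0.32 log units; beyond the scatter). For compound 4 the estimate is 9000 nM, with an expected range of 2000 nM to 35000 nM.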

Compound 4, half-maximal effective concentration: > 28700 nM
Compound 4: no number, only a limit (the forecaster's own chance of this, stated with the estimate: 25%); at least 3.1-fold (0.50 log units) between middle value and limit.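

In this assay compound 4 gives > 28700 nM, which is a limit of the assay and not a number. Among the compounds shown here, the step reads an at least 1.5-fold higher number from compound 2 to compound 4 (0.17 log units; that floor lies within the scatter): this is the first measured change on the chain, and heptyl in place of hydrogen on a saturated chain carbon, two bonds along the chain from an aromatic carbon, does not bring the number down, though its floor lies within the scatter and the real size of the step cannot be read. The chain thus joins the halogen as a second place in the series where a single change ends in a limit and not in a number: the limit of > 28700 nM in this assay, at which 1 of the 4 values shown sits.

Open is how the number runs with chain length at this place, since only the short chain of compound 2 and the long chain of compound 4 are shown, and the second of these gives no number. A butyl chain, or a chain ending in an amine or a carboxylic acid at this place, could show whether a change here ever gives a number that can be read against compound 2.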